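The compounds below may be only part of what the source reports. "The series", "measured", "known", "first", "only" and "open" are said of these compounds alone.

Measured so far in the series:
compound 1 `COc1ccccc1S(=O)(=O)/C=C/c1ccccn1`: 100%
compound 2 `COc1ccc(S(=O)(=O)/C=C/c2ccccn2)cc1`: 100%
compound 3 `COc1ccccc1S(=O)(=O)/C=C/c1cccnc1`: 100%

All three were run in an ADME assay on BV-2 cells (Mus musculus) for cytotoxicity, with a stated time of 24 h, tested at 10 uM; on this read-out higher numbers stand for a weaker effect at the one concentration tested and lower numbers for a stronger effect. Compound 1 and compound 3 share a core and differ by pyridin-3-yl in place of pyridin-2-yl on a double-bonded chain carbon bound to a double-bonded chain carbon; the measured step is no change at the digits printed from compound 1 to compound 3 (within the scatter). How the core of compound 2 differs from that of compound 1 is not broken down here; compound 2 sits level with compound 1 and compound 3 within the scatter, so no order can be drawn among the three.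

Compound 4 `COc1ccc(S(=O)(=O)/C=C/c2cccnc2)cc1` is not yet measured. It differs from compound 2 by pyridin-3-yl in place of pyridin-2-yl on a double-bonded chain carbon bound to a double-bonded chain carbon, the same change as between compound 1 and compound 3, made at the same place. In this assay the estimated step is no change at the digits printed from compound 2 to compound 4 (within the scatter), which rests on no change at the digits printed from compound 1 to compound 3 (within the scatter) having stayed within the scatter. Compound 4 is therefore expected to give 100%, between 90% and 100%.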

Compound 4, a percentage reported as activity, at one concentration (the size of the read-out at that concentration, not a potency): 99.5%
The estimate for compound 4 lay 0.5 percentage points above the measured number; the measured number falls inside the stated range.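

In this assay, pyridin-3-yl in place of pyridin-2-yl gives a number 0.5 percentage points lower from compound 2 to compound 4 (within the scatter). Set beside the earlier step, the change carries from one core to the other with no difference that can be told apart: the same change on two cores in this assay, no change at the digits printed (within the scatter) from compound 1 to compound 3 and a number 0.5 percentage points lower (within the scatter) from compound 2 to compound 4, 0.5 percentage points apart, within the scatter of two such steps

This shows only that the read-out stays level on these two cores, under the one set of conditions tested; it does not show how the change would carry on a core with a stronger effect in this assay, or in any other read-out.

Open, as far as these compounds go, is whether a group other than these two pyridinyl groups, such as an amine or a carboxylic acid, on a double-bonded chain carbon bound to a double-bonded chain carbon would move the read-out. Also open, from the compounds shown here alone, is whether any change to the shared core would produce a stronger effect.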